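A few compounds are considered here, and "the series" means these few. Any claim that something is new, unique, unknown or untested is made for them only; others in the source may bear on it.

Measured compounds and their values in an assay on HEK293 cells for agonist activity at Bile acid receptor (Homo sapiens); on this read-out higher numbers stand for larger maximal responses and lower numbers for smaller maximal responses:

Compound 1 `CO[C@]1(c2ccc(OCc3c(-c4c(Cl)cccc4Cl)noc3C3CC3)cc2Cl)C[C@H](c2cccc(C(=O)O)c2)C1`: 75%
Compound 2 `O=C(O)c1cccc(C2CC2c2ccc(OCc3c(-c4c(Cl)cccc4Cl)noc3C3CC3)cc2Cl)c1`: 87%
Compound 3 `Clc1cc(OCc2c(-c3c(Cl)cccc3Cl)noc2C2CC2)ccc1C1CC1c1ccc(-c2nnn[nH]2)nc1`: 79%

Compound 2 has the highest of the three numbers in this assay; compound 3 lies closest to it, and compound 1 furthest away. Going by the values given here, the one measured step, a number 8 percentage points lower from compound 2 to compound 3 (within the scatter), stays within the scatter, so there is no real movement between compound 2 and compound 3. Among the compounds with values here, compound 1 and compound 2 share no single-change step, so their two values can only be set side by side.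

Compound 4 `O=C(O)c1cccc([C@H]2C[C@@H]2c2ccc(OCc3c(-c4c(Cl)cccc4Cl)noc3C3CC3)cc2Cl)c1` shares all atoms and bonds with compound 2 and differs only in how the stereocentres are drawn: the two compounds have the same atoms and bonds; at least one stereo element is drawn with a configuration in one of them and without one in the other: 2 of 2 stereo elements differ; a stereocentre at a saturated ring carbon is drawn without a configuration in compound 2 and S in compound 4; a stereocentre at a saturated ring carbon is drawn without a configuration in compound 2 and S in compound 4

Within the data shown here, no measured step shows what drawing a configuration alone does to this assay, so nothing shows whether compound 4 should move at all. With the same atoms and bonds, the expectation is a step of about a number 3 percentage points lower from compound 2 to compound 4 (within the scatter), not beyond the scatter. Compound 4 is therefore estimated at 84%, with a likely range from 62% to 100%.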

Compound 4, largest response reached (reported as efficacy), in percent of the reference or control that the assay uses: 88%
Compound 4: the middle estimate sits 4 percentage points below what was measured, and the stated range covers the measured number.
By their numbers in this assay, from the lowest: compounds 1, 3, 2 and 4 (each within the scatter of the next, the first and the last beyond it).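

In this assay, going by these compounds alone, the earlier compounds gave no view of what a drawn configuration does at the two saturated ring carbons, and now there is one: a number 1 percentage points higher from compound 2 to compound 4 (within the scatter). This step lies within the scatter, so compound 4, with both carbons drawn as S, cannot be told apart from compound 2, which has no configuration drawn. The only thing that separates the two is this: the fact that one of compounds 2 and 4 is drawn with a defined configuration and the other without, at the place where they differ

Still open, going by these compounds, is how a compound with the R configuration at either of these carbons would read, as neither compound 2 nor compound 4 shows one on its own. Also open, on these data alone, is whether a sulfonic acid or a primary amide, in place of the carboxylic acid on the 3-carboxyphenyl group, would keep a response of this size.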